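The source may hold more compounds than are shown below. What is called first, only, known or untested is meant among the compounds shown, and "the series" means these compounds.

Compound 1 `CC1(C)N(O)C(c2ccc(OCC(=O)NCCCC[C@H](N)C(=O)O)cc2)=[N+]([O-])C1(C)C`: 90600 nM
Compound 2 `CC(C)(C)OC(=O)N[C@@H](CCCCNC(=O)COc1ccc(C2=[N+]([O-])C(C)(C)C(C)(C)N2O)cc1)C(=O)O`: 89900 nM

In a functional assay on PC-12 cells (Rattus norvegicus) for inhibition, read by MTT assay (on this read-out higher numbers stand for an effect only at larger amounts of compound and lower numbers for an effect already at smaller amounts), compound 2 gives 89900 nM, and compound 1 sits within the scatter of that, as a 1.0-fold lower number from compound 1 to compound 2 (0.00 log units; within the scatter) shows. Compound 3 `C[C@H](NC(=O)[C@@H]1CCCN1)C(=O)N[C@@H](CCCCNC(=O)COc1ccc(C2=[N+]([O-])C(C)(C)C(C)(C)N2O)cc1)C(=O)O` differs from compound 2 by 1-(((pyrrolidin-2-yl)carbonyl)amino)ethyl in place of tert-butoxy on a carbonyl carbon. Among the compounds with values here, the only measured step, a 1.0-fold lower number from compound 1 to compound 2 (0.00 log units; within the scatter), altered the group on the same amine nitrogen and moved nothing beyond the scatter; it offers weak guidance for this larger exchange, so no step beyond the scatter is expected. Compound 3 is therefore estimated at 90000 nM, in a range of 40000 nM to 200000 nM, meaning an expected step of a 1.0-fold higher number from compound 2 to compound 3 (0.00 log units; within the scatter).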

Compound 3, half-maximal effective concentration: 89000 nM
Estimate against measurement, compound 3: 1.0-fold (0.00 log units) above; the measured number falls inside the stated range.
By their numbers in this assay, from the lowest: compounds 3, 2 and 1 (each within the scatter of the next).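

In this assay the much larger 1-(((pyrrolidin-2-yl)carbonyl)amino)ethyl, with its ring and two defined stereocentres, can take the place of tert-butoxy on this carbonyl carbon without a step beyond the scatter (a 1.0-fold lower number from compound 2 to compound 3 (0.00 log units; within the scatter)). The full group on the amine nitrogen likewise stays within the scatter of plain hydrogen (a 1.0-fold lower number from compound 1 to compound 3 (0.01 log units; within the scatter)), so this nitrogen has now tolerated a small and a large substituent alike. No measurement here offers an explanation for this result.

From the compounds shown here alone, whether a benzoyl group or a long alkyl chain on this nitrogen would also leave the number unmoved remains open. So does whether any change to the shared core would produce a step beyond the scatter.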